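This account rests on a few compounds, and the source may have more. Where it says the series, first, only, none or still open, it means among the compounds named here.

Compound 1 `CC1=CC[C@H](C(C)(C)NC(=S)N/N=C/c2ccc(F)cc2)CC1`: in a functional assay on HT-29 cells (Homo sapiens) for inhibition, read by sulforhodamine B assay, with a stated time of 48 h (a lower number here means a stronger inhibitor of growth, a higher number a weaker inhibitor of growth), compound 1 reaches only the assay limit, > 100000 nM.
Compound 2 `CC1=CC[C@H](C(C)(C)NC(=S)N/N=C/c2ccccc2Cl)CC1`: in this assay compound 2 likewise stops at the limit, > 100000 nM.
Compound 3 `CC1=CC[C@H](C(C)(C)NC(=S)N/N=C/c2ccc[nH]2)CC1`: in this assay compound 3 also sits at the limit, > 100000 nM.

Compound 3 therefore stands nowhere above or below its neighbours on the numbers shown; all three values are limits. The steps a step that the two limits leave unreadable from compound 1 to compound 2, a step that the two limits leave unreadable from compound 1 to compound 3 and a step that the two limits leave unreadable from compound 2 to compound 3 stay unreadable because of the limit of > 100000 nM in this assay, at which 3 of the 3 values shown sit.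

Compound 4 `CC1=CC[C@H](C(C)(C)NC(=S)N/N=C/c2cccs2)CC1` differs from compound 3 by thiophen-2-yl in place of 1H-pyrrol-2-yl on a carbon with a double bond to nitrogen. For the measured compounds named here, none of the measured steps touches a thiophen-2-yl group, and none of them gives a readable size, so no direction can be taken from them. Compound 4 is therefore expected to remain at the limit, estimated at 100000 nM with a range of 30000 nM to 300000 nM. The expected step of a number no higher from compound 3 to compound 4 (the limit leaves the size open) is accordingly no step beyond the scatter.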

Compound 4, concentration for total growth inhibition: 57800 nM
The estimate for compound 4 lay 1.7-fold (0.24 log units) above the measured number; the range from low to high includes it.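

Thiophen-2-yl on the carbon with a double bond to nitrogen gives the first reading in this assay that is a number and not a limit. The steps are an at least 1.7-fold lower number from compound 3 to compound 4 (0.23 log units; that floor lies within the scatter), an at least 1.7-fold lower number from compound 2 to compound 4 (0.23 log units; that floor lies within the scatter) and an at least 1.7-fold lower number from compound 1 to compound 4 (0.23 log units; that floor lies within the scatter). Their true sizes stay open because the other three compounds give only limits: the limit of > 100000 nM in this assay, at which 3 of the 4 values shown sit.

From the compounds shown here alone, what a furan-2-yl or a 4-aminophenyl group at this place would give remains open. Also open, going by these compounds, is whether the sulfur atom or the loss of the pyrrole donor matters for the reading.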